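The compounds below may be only part of what the source reports. "The series", "measured", "known", "first", "only" and "open" are said of these compounds alone.

Measured so far in a functional assay on MCF7 cells (Homo sapiens) for inhibition, read by spectrophotometry and sulforhodamine B assay, with a stated time of 48 h; a higher number here means a weaker inhibitor of growth, a lower number a stronger inhibitor of growth:
compound 1 `Cc1ccc(N2C(=O)CS/C2=N/N=C/c2c[nH]c3ccc(Br)cc23)cc1`: 59500 nM
compound 2 `Cc1ccc(NC(=S)N/N=C/c2c[nH]c3ccccc23)cc1`: 2520 nM

Compound 1 has the higher of the two numbers, which makes it the weaker growth inhibitor of this pair, and the gap to compound 2 lies beyond the usual scatter. The two compounds differ in more than one place, so this gap cannot be assigned to any single structural feature.

Compound 3 `Cc1ccc(N2C(=O)CS/C2=N/N=C/c2c[nH]c3ccccc23)cc1` has not yet been measured. It keeps the core of compound 1 and changes at one point: hydrogen in place of bromo on an aromatic carbon. Going by the values given here, no measured pair isolates this change, so its size remains uncertain. A moderate move toward a lower number is expected, as compound 2 at 2520 nM also carries hydrogen at this place, but this is only indirect support. The expected change is a 2.7-fold lower number from compound 1 to compound 3 (0.43 log units; beyond the scatter), and a result within the scatter of compound 1 would not be surprising. For compound 3 the estimated value is 22000 nM, with an expected range of 5000 nM to 70000 nM.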

Compound 3, concentration for 50% growth inhibition: > 100000 nM
Compound 3: no number, only a limit (the forecaster's own chance of this, stated with the estimate: 8%); at least 4.5-fold (0.65 log units) between middle value and limit.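

Going by these compounds alone, this is the first pair that isolates this position: in this assay, hydrogen in place of bromo on the aromatic carbon gives an at least 1.6-fold higher number from compound 1 to compound 3 (0.22 log units; that floor lies within the scatter), so the change shows no move toward a lower number, and the floor of the step does not by itself establish a difference beyond the usual scatter. Compound 3 gives > 100000 nM, which is a limit of the assay and not a number. With hydrogen at this place, the core of compound 1 therefore gives no measured growth inhibition value, and the full size of the step cannot be read because compound 3 stands at that limit: the limit of > 100000 nM in this assay, at which 1 of the 3 values shown sits.

The compounds shown leave open whether bromo itself matters at this place or whether another group, such as chloro, methoxy or nitrile, would serve equally well on the same aromatic carbon. They also leave open whether bromo at this place would change the number for compound 2 in the same direction, and whether the step holds when the aryl methyl group of the shared core is replaced by a carboxylic acid or an amine.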